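Propyl for Isopropyl on the Core Nitrogen: Tolerance Outlook

This account rests on a few compounds, and the source may have more. Where it says the series, first, only, none or still open, it means among the compounds named here.

Compound 1, `COc1ccc(-c2cnc(NC(=O)c3ccc(F)cc3)n2C(C)C)cc1`, gives only a limit of > 50000 nM in a toxicity assay on THP-1 cells (Homo sapiens) for inhibition; a higher number here means that more compound is tolerated, a lower number that less compound is tolerated.
Compound 2, `COc1ccc(-c2cnc(NC(=O)c3cnc[nH]3)n2C)cc1`, gives only a limit of > 100000 nM in this assay.
Compound 3, `COc1ccc(-c2cccc(NC(=O)c3ccc(F)cc3)n2)cc1`, gives only a limit of > 100000 nM in this assay.

None of the three measured compounds has a numerical value: compound 1 sits at the limit of > 50000 nM in this assay, at which 1 of the 3 values shown sits, while the other two sit at the limit of > 100000 nM in this assay, at which 2 of the 3 values shown sit. Compound 4, `CCCn1c(-c2ccc(OC)cc2)cnc1NC(=O)c1ccc(F)cc1`, keeps every atom of compound 1 but joins them differently: propyl in place of isopropyl on an aromatic nitrogen. Such a small change gives no reason to expect a shift beyond the usual scatter in this assay, so the step of a number no higher from compound 1 to compound 4 (the limit leaves the size open) is expected to be nil. Compound 4 is therefore estimated at 50000 nM, between 20000 nM and 150000 nM, most likely again reported only as a limit.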

Compound 4, half-maximal cytotoxic concentration: > 100000 nM
Compound 4: only a limit was reported; the forecaster's own chance of this, stated with the estimate: 85%; at least 2.0-fold (0.30 log units) between middle value and limit.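

Going by these compounds alone, compound 1 and compound 4 are both reported only as limits, so no step between them can be read in this assay. The compounds shown leave open at what concentration any of them harms these cells.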